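Propylamino in place of methylamino on the shared core

A few compounds are considered here, and "the series" means these few. Any claim that something is new, unique, unknown or untested is made for them only; others in the source may bear on it.

Measured compounds in a functional assay on SW480 cells (Homo sapiens) for inhibition, read by luminescence and resazurin assay, with a stated time of 3 days; on this read-out higher numbers stand for weaker inhibition and lower numbers for stronger inhibition:
compound 1 `CNc1nc(NCc2ccc(C(=O)NC3CCN(Cc4ccc(F)cc4)CC3)cc2)c2cc(C)ccc2n1` gives 1300 nM.
compound 2 `CN(C)c1nc(NCc2ccc(NC(=O)c3ccncc3)cc2)c2ccccc2n1` gives 11000 nM.
compound 3 `CCNc1ncc(C)c(NCc2ccc(NC(=O)c3ccc(F)cc3)cc2)n1` returns only a limit of the assay, > 20000 nM.

Compound 1 holds the lowest of the two numbers obtained; compound 2 sits higher by a gap that lies beyond the usual scatter. One of the three results is a limit and not a number (the limit of > 20000 nM in this assay, at which 1 of the 3 values shown sits). For the measured compounds named here, no pair of measured compounds differs in a single place, so no measured step is available within the set, and compounds 2 and 3 share neither the amide arrangement nor the core of compound 1.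

Compound 4 `CCCNc1nc(NCc2ccc(C(=O)NC3CCN(Cc4ccc(F)cc4)CC3)cc2)c2cc(C)ccc2n1` has not been measured. It differs from compound 1 by ethyl in place of hydrogen on a saturated chain carbon bound to a nitrogen on an aromatic ring; the same change read one bond further out is methylamino to propylamino. Going by the values given here, with no measured step to lean on, the expectation rests on the small size of the change: no step beyond the scatter, in either direction, is expected for a 1.2-fold higher number from compound 1 to compound 4 (0.06 log units; within the scatter). Compound 4 is therefore estimated at 1500 nM, within a range from 500 nM to 4500 nM.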

Compound 4, half-maximal inhibitory concentration: 1100 nM
For compound 4 the middle estimate is 1.4-fold (0.13 log units) above the measured one, and the stated range covers the measured number.
By their numbers in this assay, from the lowest: compounds 4 and 1 (each within the scatter of the next); then compound 2. At a limit, above all of these: compound 3.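

In this assay, for the compounds shown here, the first step in one place reads a 1.2-fold lower number from compound 1 to compound 4 (0.07 log units; within the scatter) and so gives no change beyond the scatter. Going by these compounds alone, on a saturated chain carbon bound to a nitrogen on an aromatic ring, ethyl in place of hydrogen therefore leaves the read-out where it was, and methylamino and propylamino cannot be told apart on the core of compound 1, which the earlier compounds could not show. Nothing available bears on why the read-out holds across this change.

Going by these compounds, whether a longer chain such as hexylamino, or a chain ending in an amine or a carboxylic acid, would hold the number as well stays open. Compounds 2 and 3 differ from compound 1 in more than one place, so the separate effects of the amide arrangement and the core cannot be read.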